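The source may hold more compounds than are shown below. What is called first, only, known or untested is meant among the compounds shown, and "the series" means these compounds.

Compound 1 `COc1ccccc1-c1ccc2ncn(-c3cc(OC)c(OC)c(OC)c3)c2c1` is one of two compounds tested in a functional assay on A549 cells (Homo sapiens) for antiproliferative activity, read by MTT assay, with a stated time of 72 h (a higher number here means a weaker inhibitor, a lower number a stronger inhibitor), and compound 1 gives 4320 nM. Compound 2 `COc1cc(-n2cnc3ccc(-c4ccc(C)cc4F)cc32)cc(OC)c1OC` differs from it only at the group on an aromatic carbon of the shared core. For compound 2 the result is a limit of the assay, > 10000 nM, not a number. The step of an at least 2.3-fold higher number from compound 1 to compound 2 (0.36 log units; beyond the scatter) is therefore at least modest, and it rests on (the limit of > 10000 nM in this assay, at which 1 of the 2 values shown sits).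

Compound 3 `COc1cc(-n2cnc3ccc(-c4cccc(Cl)c4)cc32)cc(OC)c1OC` is not yet measured. Its change from compound 1 is 3-chlorophenyl in place of 2-methoxyphenyl on an aromatic carbon. Going by the values given here, the only measured step, from compound 1 to compound 2, also exchanged the 2-methoxyphenyl for a different substituted phenyl and weakened inhibition. On that basis a step of similar size and direction is expected here, with a fair chance that the result is again only a limit. For compound 3 the expected step is a 2.1-fold higher number from compound 1 to compound 3 (0.32 log units; beyond the scatter), and the estimated value of compound 3 in this assay is 9000 nM, within a range from 3000 nM to 27000 nM.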

Compound 3, half-maximal inhibitory concentration: 7050 nM
Compound 3: middle estimate off by 1.3-fold (0.11 log units), on the high side; the measured number falls inside the stated range.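

Placing 3-chlorophenyl at this aromatic carbon in place of 2-methoxyphenyl gives a 1.6-fold higher number from compound 1 to compound 3 (0.21 log units; within the scatter) in this assay, so not every exchange of the 2-methoxyphenyl moves the number beyond the scatter, and compound 3 goes against any such rule. Between the two replacement rings the reading is an at least 1.4-fold lower number from compound 2 to compound 3 (0.15 log units; that floor lies within the scatter), so these data do not separate 3-chlorophenyl from 2-fluoro-4-methylphenyl. Compound 2 has a limit of the assay, > 10000 nM, not a number, and the size of this second step stays uncertain because of that limit: the limit of > 10000 nM in this assay, at which 1 of the 3 values shown sits.

With only substituted phenyl rings at this position, the compounds shown cannot say which feature of these rings governs the activity. From the compounds shown here alone, it also remains open how the position responds to a phenyl ring carrying an amine or a carboxylic acid, or to a longer chain in place of the ring.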